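This account rests on a few compounds, and the source may have more. Where it says the series, first, only, none or still open, it means among the compounds named here.

Values so far in a functional assay on BGC-823 cells (Homo sapiens) for cytotoxicity, read by MTT assay, with a stated time of 48 h; on this read-out lower numbers stand for stronger inhibition and higher numbers for weaker inhibition
- compound 1 `CN(C)CCNc1ccnc2cc(OCc3ccc(F)cc3)ccc12` gives 890 nM
- compound 2 `CN(C)CCCNc1ccnc2cc(OCc3ccc(F)cc3)ccc12` gives 490 nM
- compound 3 `C=CCOc1ccc2c(NCCCN(C)C)ccnc2c1` is not yet measured

For the measured compounds named here, the one measured step of a 1.8-fold lower number from compound 1 to compound 2 (0.26 log units; within the scatter) separates nothing, so compound 2 stands level with the only other measured number. The change to compound 3 is vinyl in place of 4-fluorophenyl on a saturated chain carbon bound to an oxygen on an aromatic ring (in short, 4-fluorobenzyl to allyl). The measured step lies elsewhere in the molecule, so it sets no size for this change. A move to a higher number in this assay is expected, with a 6.1-fold higher number from compound 2 to compound 3 (0.79 log units; beyond the scatter) as the estimated step. For compound 3 the estimate is 3000 nM with an expected range from 800 nM to 12000 nM on this limited evidence.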

Compound 3, half-maximal inhibitory concentration: 6680 nM
Compound 3: middle estimate off by 2.2-fold (0.35 log units), on the low side; low and high end bracket the measured number.
By their numbers in this assay, from the lowest: compounds 2 and 1 (each within the scatter of the next); then compound 3.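

In this assay the change from 4-fluorobenzyl to allyl gives a 14-fold higher number from compound 2 to compound 3 (1.13 log units; beyond the scatter) and so, unlike the earlier step in the amine chain, moves the number beyond the scatter. The aromatic ring and its fluorine leave together, so this step cannot assign the loss to either one. Nothing available bears on the reason for the step.

On these data alone, whether a plain benzyl, with the ring kept and the fluorine gone, stands nearer compound 2 or compound 3 remains open. Also open, as far as these compounds go, is how a saturated propyl compares with allyl.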